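From Methyl to Chloro: Expected Thymidylate Synthase Inhibition

A few compounds are considered here, and "the series" means these few. Any claim that something is new, unique, unknown or untested is made for them only; others in the source may bear on it.

Compound 1 `N=c1scc(-c2ccccc2)n1CC(=O)N1CCOCC1`: 6220 nM
Compound 2 `Cc1ccc(-c2csc(=N)n2CC(=O)N2CCOCC2)cc1`: 4060 nM

In an assay on isolated protein for inhibition of Thymidylate synthase (Homo sapiens) (on this read-out lower numbers stand for stronger inhibition and higher numbers for weaker inhibition), compound 2 stands at the lower of the two numbers; the gap to compound 1, a 1.5-fold lower number from compound 1 to compound 2 (0.19 log units; within the scatter), is within the scatter. Compound 3 `N=c1scc(-c2ccc(Cl)cc2)n1CC(=O)N1CCOCC1` differs from compound 2 by chloro in place of methyl on an aromatic carbon. Among the measured compounds shown here, the one measured step, a 1.5-fold lower number from compound 1 to compound 2 (0.19 log units; within the scatter), concerns a different exchange on that carbon and is no direct guide, but it shows a small change there moving the number little. Compound 3 is therefore expected to lie close to compound 2, with an estimated step of a 1.2-fold lower number from compound 2 to compound 3 (0.06 log units; within the scatter), not beyond the scatter. The estimate for compound 3 in this assay is 3500 nM, ranging from 1500 nM to 8000 nM.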

Compound 3, inhibition constant: 3730 nM
Compound 3: the middle estimate sits 1.1-fold (0.03 log units) below what was measured, within the range that was stated.
By their numbers in this assay, from the lowest: compounds 3, 2 and 1 (each within the scatter of the next).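

In this assay the change from 4-methylphenyl to 4-chlorophenyl gives a 1.1-fold lower number from compound 2 to compound 3 (0.04 log units; within the scatter) and chloro in place of hydrogen gives a 1.7-fold lower number from compound 1 to compound 3 (0.22 log units; within the scatter) on the same aromatic carbon. At this place, para to a large group, chloro therefore joins methyl in leaving the number within the scatter of the unsubstituted compound 1. No evidence at hand bears on this result. The compounds shown leave open whether an amine or a carboxylic acid at this carbon would give a step beyond the scatter. They also leave open what a change elsewhere on the shared core would do.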